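Methyl to ethyl on the thiazole: a repeated step

This account rests on a few compounds, and the source may have more. Where it says the series, first, only, none or still open, it means among the compounds named here.

Measured so far:
compound 1, `CCc1nc(Cc2c[nH]cn2)c(CC)s1`, 1.8 mg/kg
compound 2, `CCc1nc(Cc2c[nH]cn2)c(C)s1`, > 30 mg/kg
compound 3, `Cc1nc(Cc2c[nH]cn2)sc1C`, 1.7 mg/kg

In a functional assay on the whole organism (Abdomen) with Mus musculus as the target (a higher number here means that more compound is needed for the effect, a lower number that less compound is needed), compound 1 gives 1.8 mg/kg and compound 3 gives 1.7 mg/kg, the two within the scatter of each other. Compound 2 reaches only a limit, > 30 mg/kg, at the limit of > 30 mg/kg in this assay, at which 1 of the 3 values shown sits. The change from compound 2 to compound 1 is methyl in place of hydrogen on a saturated chain carbon bound to an aromatic carbon, and it made an at least 16-fold lower number from compound 2 to compound 1 (1.22 log units; beyond the scatter).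

Compound 4, `CCc1sc(Cc2c[nH]cn2)nc1C`, is not yet measured. It differs from compound 3 by methyl in place of hydrogen on a saturated chain carbon bound to an aromatic carbon, the same change at the same place as that from compound 2 to compound 1. How the core of compound 3 differs from the core of compound 2 is not broken down here.

Beside the earlier step, the expectation for compound 4 in this assay is a lowering, a 2.8-fold lower number from compound 3 to compound 4 (0.45 log units; beyond the scatter), resting on the step from compound 2 to compound 1, an at least 16-fold lower number from compound 2 to compound 1 (1.22 log units; beyond the scatter), though its full size is unknown since compound 2 sits at a limit. The estimate for compound 4 is 0.6 mg/kg, expected between 0.2 mg/kg and 2 mg/kg.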

Compound 4, dose for half-maximal effect: 2.8 mg/kg
Compound 4: middle estimate off by 4.7-fold (0.67 log units), on the low side, and the stated range ends below it.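

On the core of compound 3, methyl in place of hydrogen gives a 1.6-fold higher number from compound 3 to compound 4 (0.22 log units; within the scatter), so the large drop in the number seen on the other core does not recur here. The change therefore does not carry over between these two cores in this assay: the same change on two cores in this assay, an at least 16-fold lower number (1.22 log units; beyond the scatter) from compound 2 to compound 1 and a 1.6-fold higher number (0.22 log units; within the scatter) from compound 3 to compound 4, at least 27-fold (1.43 log units) apart, beyond the scatter of two such steps Compound 2 gives > 30 mg/kg, which is a limit and not a number, so the full size of the earlier step remains unknown, and nothing here shows why the two cores differ: the limit of > 30 mg/kg in this assay, at which 1 of the 4 values shown sits.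

The compounds shown leave open how a longer chain, such as propyl, would behave at this place on either core. They also leave open how the same change would behave on any further core.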